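From Methoxy to Hydroxy: Expecting Compound 3

The source may report more compounds than this note shows. Statements on the series, on what has been measured and on what is new or still open speak of the compounds shown alone.

Compound 1 `COc1cc(-c2nn(-c3cccc(NC(=O)c4cccc(C(F)(F)F)c4)c3)cc2-c2ccncc2)ccc1Cl`: 27000 nM
Compound 2 `COc1cc(-c2nn(-c3cccc(NC(=O)Nc4ccc(Cl)c(C(F)(F)F)c4)c3)cc2-c2ccncc2)ccc1Cl`: > 32500 nM

Both measured compounds were tested in a functional assay on NCI-H226 cells (Homo sapiens) for inhibition, read by sulforhodamine B assay, with a stated time of 48 h; on this read-out lower numbers stand for stronger inhibition of growth and higher numbers for weaker inhibition of growth. Compound 1 gives a plain number, 27000 nM. For compound 2 the assay returns only a limit, not a number, namely > 32500 nM, which is the limit of > 32500 nM in this assay, at which 1 of the 2 values shown sits. Within the data shown here, the one measured step, an at least 1.2-fold higher number from compound 1 to compound 2 (0.08 log units; that floor lies within the scatter), replaces 3-(trifluoromethyl)phenyl with (4-chloro-3-(trifluoromethyl)phenyl)amino on a carbonyl carbon and lies within the scatter.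

Compound 3 `O=C(Nc1cccc(-n2cc(-c3ccncc3)c(-c3ccc(Cl)c(O)c3)n2)c1)Nc1ccc(Cl)c(C(F)(F)F)c1` differs from compound 2 in a single place: hydrogen in place of methyl on an oxygen on an aromatic ring. Cut one bond further out, methoxy becomes hydroxy, so 4-chloro-3-methoxyphenyl becomes 4-chloro-3-hydroxyphenyl. Among the measured compounds shown here, no measured step touches this part of the shared core; the only step known concerns the carbonyl side. Nothing here therefore argues for a change beyond the scatter, and the starting point is itself a limit. Compound 3 is expected to give about 35000 nM, with a range from 12000 nM to 100000 nM. The step expected is a step that the limit leaves unreadable from compound 2 to compound 3, and a limit rather than a number is quite likely to be reported again.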

Compound 3, concentration for total growth inhibition: > 32500 nM
Compound 3: a limit, no number (the forecaster's own chance of this, stated with the estimate: 60%); the middle value is on the limit's open side.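

In this assay compound 3 returns only a limit (> 32500 nM), and compound 2 also returns a limit, so no step can be read between these two compounds. Both sit at the same ceiling of the assay: the limit of > 32500 nM in this assay, at which 2 of the 3 values shown sit. From the compounds shown here alone, whether methoxy or hydroxy gives stronger inhibition of growth stays open, since neither compound has a plain number.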